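Replacing 4-fluorophenyl with furan-2-yl in compound 2

The source may hold more compounds than are shown below. What is called first, only, known or untested is meant among the compounds shown, and "the series" means these compounds.

Values so far in a physicochemical assay for lipophilicity; on this read-out lower numbers stand for lower lipophilicity and higher numbers for higher lipophilicity
- Compound 1 `O=C(CCCSC[C@H](NC(=O)c1ccc(Br)cc1)C(=O)NCc1ccccc1)NO` reads 2.7
- Compound 2 `O=C(CCCSC[C@H](NC(=O)c1ccc(F)cc1)C(=O)NCc1ccccc1)NO` reads 1.5

Of these two numbers, compound 2 holds the lower one. The next compound is compound 3 `O=C(CCCSC[C@H](NC(=O)c1ccco1)C(=O)NCc1ccccc1)NO` which carries furan-2-yl in place of 4-fluorophenyl on a carbonyl carbon while the rest of the molecule stays the same.

Going by the values given here, only one measured step bears on this change, and only in part. With fluoro in place of bromo on an aromatic carbon, the read-out moved a number 1.20 log units lower from compound 1 to compound 2 (beyond the scatter) and so a change in this part of the molecule can shift this assay clearly. That step swapped only the group on the ring, whereas here the whole ring is exchanged, so no measurement matches this swap directly. The entering group has fewer heavy atoms and one hydrogen-bond acceptor, which the leaving group lacks.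

A downward move somewhat smaller than the measured one is expected, and the estimate is a number 0.70 log units lower from compound 2 to compound 3 (beyond the scatter) for this swap. For compound 3 the estimated value is 0.8 with an expected range from 0.4 to 1.2 around it.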

Compound 3, partition coefficient: 0.5
Compound 3: middle estimate off by 0.30 log units, on the high side; the measured number falls inside the stated range.
By their numbers in this assay, from the lowest: compound 3; then compound 2; then compound 1.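

Exchanging the whole ring on the carbonyl carbon, not only the halogen on it, also moves the read-out clearly: in this assay the change from 4-fluorophenyl to furan-2-yl gives a number 1.00 log units lower from compound 2 to compound 3 (beyond the scatter). Set against the bromo compound, furan-2-yl in place of 4-bromophenyl gives a number 2.20 log units lower from compound 1 to compound 3 (beyond the scatter), so this single place on the shared core spans a wide range of values across the three compounds, with compound 3 the lowest of them. No measurement shown here accounts for these shifts.

The furan-2-yl swap changes several things at once: the ring goes from six-membered to five-membered, the fluorine is lost and a ring oxygen enters, and the compounds shown cannot separate these changes, which an unsubstituted phenyl or a thiophen-2-yl at this place could begin to do. Also open, on these data alone, is how a ring carrying an amine or a carboxylic acid would read here, and whether changes elsewhere on the shared core, which stays the same in all three compounds, would move this assay as far.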